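Dihydroxyphenyl for dimethoxyphenyl: an expected cytotoxicity step

This account rests on a few compounds, and the source may have more. Where it says the series, first, only, none or still open, it means among the compounds named here.

Three compounds have been measured in a functional assay on MKN-45 cells (Homo sapiens) for cytotoxicity, read by MTT assay, with a stated time of 72 h; on this read-out lower numbers stand for stronger inhibition and higher numbers for weaker inhibition:
compound 1 `CN(C)CCn1cnnc1-c1cc(Oc2ccc(NC(=O)N/N=C/c3ccc(Cl)cc3)cc2F)ccn1` gives 570 nM
compound 2 `CN(C)CCn1cnnc1-c1cc(Oc2ccc(NC(=O)N/N=C/c3cc(Br)c(O)c(Br)c3)cc2F)ccn1` gives 4320 nM
compound 3 `COc1ccc(/C=N/NC(=O)Nc2ccc(Oc3ccnc(-c4nncn4CCN(C)C)c3)c(F)c2)c(OC)c1` gives 1680 nM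

Compound 3 holds the second highest number of the three, with a 2.9-fold higher number from compound 1 to compound 3 (0.47 log units; beyond the scatter) and a 2.6-fold lower number from compound 2 to compound 3 (0.41 log units; beyond the scatter). Compound 4 `CN(C)CCn1cnnc1-c1cc(Oc2ccc(NC(=O)N/N=C/c3ccc(O)cc3O)cc2F)ccn1` differs from compound 3 by 2,4-dihydroxyphenyl in place of 2,4-dimethoxyphenyl on a carbon with a double bond to nitrogen. For the measured compounds named here, the steps that bear on this change are a 7.6-fold higher number from compound 1 to compound 2 (0.88 log units; beyond the scatter), where the entering ring carries a hydroxyl, and a 2.6-fold lower number from compound 2 to compound 3 (0.41 log units; beyond the scatter), where the hydroxyl-bearing ring leaves. Both point to higher numbers for rings with hydroxyls in this assay, so a modest step upward is expected: a 1.6-fold higher number from compound 3 to compound 4 (0.21 log units; within the scatter). Compound 4 is accordingly estimated at 2700 nM, within a range of 1000 nM to 7500 nM.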

Compound 4, half-maximal inhibitory concentration: 2860 nM
Compound 4: middle estimate off by 1.1-fold (0.03 log units), on the low side; low and high end bracket the measured number.
By their numbers in this assay, from the lowest: compound 1; then compounds 3, 4 and 2 (each within the scatter of the next, the first and the last beyond it).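

In this assay, exchanging the 2,4-dimethoxyphenyl group for 2,4-dihydroxyphenyl on this carbon gives no clear change (with a 1.7-fold higher number from compound 3 to compound 4 (0.23 log units; within the scatter)). The 3,5-dibromo-4-hydroxyphenyl group cannot be separated from it either (with a 1.5-fold lower number from compound 2 to compound 4 (0.18 log units; within the scatter)), whereas the 4-chlorophenyl group stays clearly apart (with a 5.0-fold higher number from compound 1 to compound 4 (0.70 log units; beyond the scatter)), leaving compound 1 with the lowest number of the four. Nothing available explains these differences. Still open, going by these compounds, is whether the chlorine of the 4-chlorophenyl group itself goes with that lower number, and where a ring carrying an amine or a carboxylic acid would fall.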